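Shortening the link to a pyridine on a dithiocarbamate nitrogen

The compounds below may be only part of what the source reports. "The series", "measured", "known", "first", "only" and "open" are said of these compounds alone.

Measured so far in a functional assay on HeLa cells (Homo sapiens) for antiproliferative activity, read by CCK-8 assay, with a stated time of 72 h, tested at 8 uM; on this read-out higher numbers stand for a stronger effect at the one concentration tested and lower numbers for a weaker effect:

compound 1 `CC1CCCCN1C(=S)SCc1ccc(C(=O)Nc2ccccc2N)cc1` gives 76.3%
compound 2 `CN(Cc1cccnc1)C(=S)SCc1ccc(C(=O)Nc2ccccc2N)cc1` gives 68.7%
compound 3 `Nc1ccccc1NC(=O)c1ccc(CSC(=S)N2CCN(c3ccc(F)cc3)CC2)cc1` gives 64.5%

Compound 2 stands second of the three numbers, nearest to compound 3 and furthest from compound 1, yet both gaps lie within the scatter, so no order among the three can be claimed. Within the data shown here, the one step measured between neighbours, a number 7.6 percentage points lower from compound 1 to compound 2 (within the scatter), also stays within the scatter.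

Compound 4 `CN(C(=S)SCc1ccc(C(=O)Nc2ccccc2N)cc1)c1cccnc1` is not yet measured. It differs from compound 2 in one place: pyridin-3-yl in place of (pyridin-3-yl)methyl on an amide-type nitrogen. The pyridine ring thus sits directly on the nitrogen instead of one chain carbon further out.

Among the measured compounds shown here, no measured step concerns this kind of change; the step from compound 1 to compound 2 exchanges whole amines on the thiocarbonyl carbon and, being within the scatter, suggests that this nitrogen tolerates variation. Hence no step beyond the scatter is expected in this assay, and the expected step is a number 3.7 percentage points lower from compound 2 to compound 4 (within the scatter). For compound 4 the estimate is 65%, with a range from 50% to 78%.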

Compound 4, a percentage reported as inhibition, at one concentration (the size of the read-out at that concentration, not a potency): 70.5%
Compound 4: middle estimate off by 5.5 percentage points, on the low side; the measured number falls inside the stated range.
By their numbers in this assay, from the lowest: compounds 3, 2, 4 and 1 (each within the scatter of the next, the first and the last beyond it).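

In this assay, shortening the link so that pyridin-3-yl sits directly on the amide-type nitrogen gives a number 1.8 percentage points higher from compound 2 to compound 4 (within the scatter), so the two link lengths cannot be told apart at this position. Exchanging the whole 2-methylpiperidin-1-yl amine on the thiocarbonyl carbon for methyl(pyridin-3-yl)amino gives a number 5.8 percentage points lower from compound 1 to compound 4 (within the scatter), which adds a second amine of a different shape that cannot be told apart from compound 1 either. No other measurement accompanies these numbers to account for this result.

Still open, from the compounds shown here alone, is what a longer chain would do, such as 2-(pyridin-3-yl)ethyl on the same nitrogen. So is whether the ring nitrogen of the pyridine matters at all, which a plain phenyl ring in its place would test.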